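Moving one methoxy group on the benzoate ester

The source may hold more compounds than are shown below. What is called first, only, known or untested is meant among the compounds shown, and "the series" means these compounds.

Compound 1 `COC(=O)/C(=C\c1ccc(OC(=O)c2cccc(OC)c2)cc1)Sc1ccnc2cc(Cl)ccc12`: > 100000 nM
Compound 2 `COC(=O)/C(=C\c1ccc(OC(=O)c2cc(OC)cc(OC)c2OC)cc1)Sc1ccnc2cc(Cl)ccc12`: 74000 nM

In an ADME assay on cells (Lymphocyte, Homo sapiens) for cytotoxicity, read by MTT assay, with a stated time of 48 h (a higher number here means a weaker inhibitor, a lower number a stronger inhibitor), compound 1 gives only a limit, > 100000 nM (the limit of > 100000 nM in this assay, at which 1 of the 2 values shown sits). Compound 2 gives 74000 nM, the only actual number shown here. The step of an at least 1.3-fold lower number from compound 1 to compound 2 (0.13 log units; that floor lies within the scatter) lies within the scatter. Compound 3 `COC(=O)/C(=C\c1ccc(OC(=O)c2ccc(OC)c(OC)c2OC)cc1)Sc1ccnc2cc(Cl)ccc12` differs from compound 2 by 2,3,4-trimethoxyphenyl in place of 2,3,5-trimethoxyphenyl on a carbonyl carbon. Within the data shown here, the one measured step, which also changed the methoxyphenyl on that carbonyl carbon, is the only guide, and it was small. The estimated step of a 1.1-fold higher number from compound 2 to compound 3 (0.03 log units; within the scatter) is therefore expected to be none beyond the scatter. Compound 3 is estimated at 80000 nM, ranging from 35000 nM to 180000 nM.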

Compound 3, half-maximal inhibitory concentration: 22400 nM
Compound 3: the middle estimate sits 3.6-fold (0.55 log units) above what was measured; measured number outside the range, below it.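

In this assay, the arrangement of the methoxy groups on this carbonyl carbon's phenyl ring now makes a measurable difference: with the same atoms joined differently, 2,3,4-trimethoxyphenyl in place of 2,3,5-trimethoxyphenyl gives a 3.3-fold lower number from compound 2 to compound 3 (0.52 log units; beyond the scatter). Starting instead from 3-methoxyphenyl, the change gives an at least 4.4-fold lower number from compound 1 to compound 3 (0.64 log units; beyond the scatter). The value for compound 1 is only a limit: the limit of > 100000 nM in this assay, at which 1 of the 3 values shown sits.

Which of the methoxy groups accounts for the lower number remains open. So does the effect of an amine or a carboxylic acid on this ring.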